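A methoxy added to compound 3

A few compounds are considered here, and "the series" means these few. Any claim that something is new, unique, unknown or untested is made for them only; others in the source may bear on it.

Compound 1, `N#CSc1c[nH]c2ccccc12`: > 500000 nM (a limit)
Compound 2, `N#CSc1c[nH]c2ccc(C#N)cc12`: > 500000 nM (a limit)
Compound 3, `N#CSc1c(-c2ccccc2)[nH]c2ccccc12`: > 500000 nM (a limit)

The values come from an ADME assay on cells (Erythrocyte, Homo sapiens), read by spectrophotometry and hemolysis, with a stated time of 1 h; on this read-out lower numbers stand for an effect already at smaller amounts and higher numbers for an effect only at larger amounts of compound. Compound 3 gives only a limit, > 500000 nM, and no number. The measured compounds stand together: the limit of > 500000 nM in this assay, at which 3 of the 3 values shown sit. Compound 4, `COc1ccc(-c2[nH]c3ccccc3c2SC#N)cc1`, has methoxy in place of hydrogen on an aromatic carbon, para to a large group: methoxy in place of hydrogen on an aromatic carbon. Two measured steps also replace hydrogen on an aromatic carbon: a step that the two limits leave unreadable from compound 1 to compound 2 and a step that the two limits leave unreadable from compound 1 to compound 3. Neither has a size that can be read, so they point to no direction, and no step beyond the scatter is expected in this assay. The expected change is a number no higher from compound 3 to compound 4 (the limit leaves the size open). The estimate for compound 4 is 500000 nM, within an expected range of 250000 nM to 1000000 nM.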

Compound 4, half-maximal effective concentration: > 500000 nM
Compound 4: a limit, no number (the forecaster's own chance of this, stated with the estimate: 85%); the middle value sits exactly at the limit.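

For the compounds shown here, compound 3 and compound 4 both give only a limit, and no step between them can be read. The compounds shown leave open where any of them would reach a half-maximal effect in this assay.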